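The compounds below may be only part of what the source reports. "The series", "measured", "known", "first", "only" and "open" are said of these compounds alone.

Measured so far:
compound 1 `O=C([C@H]1CC2CCC1C2)N1CC(c2nc(-c3cccc(F)c3)no2)C1` gives 72 nM in an assay on HEK293 cells for positive allosteric modulation of metabotropic glutamate receptor 5 (Homo sapiens), read by FLIPR; on this read-out higher numbers stand for an effect only at larger amounts of compound and lower numbers for an effect already at smaller amounts;
compound 2 `O=C(c1ccc(F)c(F)c1)N1CC(c2nc(-c3cccc(F)c3)no2)C1` gives 3200 nM.

Compound 2 stands at the higher of the two numbers, the move a 44-fold higher number from compound 1 to compound 2 (1.65 log units; beyond the scatter) placing it well apart from compound 1. Compound 3 `O=C([C@@H]1CC2CCC1C2)N1CC(c2nc(-c3cccc(F)c3)no2)C1` is not yet measured. Compared with compound 2 it carries a group of 7 heavy atoms (7 carbon; 2 five-membered non-aromatic rings of carbon only) in place of a group of 8 heavy atoms (6 carbon, 2 fluorine; one six-membered aromatic ring of carbon only), on a carbonyl carbon. Among the compounds with values here, the one measured step that bears on this is the reverse one, a 44-fold higher number from compound 1 to compound 2 (1.65 log units; beyond the scatter), which was large; the bicyclic group entering in compound 3 is the same group that left in that step, with its stereocentre drawn the other way from compound 1. A step of comparable size in the opposite direction is therefore expected, a 21-fold lower number from compound 2 to compound 3 (1.33 log units; beyond the scatter), with the stereochemical difference from compound 1 leaving the exact size open. Compound 3 is estimated at 150 nM, within a range of 40 nM to 1200 nM.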

Compound 3, half-maximal effective concentration: 100 nM
For compound 3 the middle estimate is 1.5-fold (0.18 log units) above the measured one; the range from low to high includes it.
By their numbers in this assay, from the lowest: compounds 1 and 3 (each within the scatter of the next); then compound 2.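

With the bicyclic group drawn the other way, the exchange on the carbonyl carbon gives a 32-fold lower number from compound 2 to compound 3 (1.51 log units; beyond the scatter), so the large gap from the 3,4-difluorophenyl compound does not rest on one configuration at the saturated ring carbon. Between the two bicyclic compounds the record shows a 1.4-fold higher number from compound 1 to compound 3 (0.14 log units; within the scatter), so the read-out does not separate these two drawings of the stereocentre. That comparison carries one caution, which limits how far it can be taken as a clean test of configuration: the fact that one of compounds 1 and 3 is drawn with a defined configuration and the other without, at the place where they differ

The compounds shown leave open whether the two-ring framework is needed, or whether a single saturated ring such as cyclopentyl or cyclohexyl on the carbonyl carbon would give a similar number. They also leave open whether an unsubstituted phenyl would stand as far from the bicyclic compounds as the 3,4-difluorophenyl does.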